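The compounds below may be only part of what the source reports. "The series", "measured", "known", "first", "only" and "open" are said of these compounds alone.

Measured so far:
compound 1 `Cc1n[nH]c2ccc(-c3nc4cnc(N5CCN(C)CC5)cn4c3Nc3ccc(I)cc3)cc12` — "not determined" (no result reported) in a functional assay on MV4-11 cells (Homo sapiens) for inhibition, with a stated time of 120 h; a lower number here means a stronger inhibitor, a higher number a weaker inhibitor
compound 2 `Cc1n[nH]c2ccc(-c3nc4cnc(N5CCN(C)CC5)cn4c3Nc3ccc(Cl)cc3F)cc12` — 10400 nM in this assay

Compound 2 stands alone on the numbers shown: in this assay compound 2 gives 10400 nM, and compound 1 has no number in this assay to set beside it. Compound 3 `Cc1cc(Br)ccc1Nc1c(-c2ccc3[nH]nc(C)c3c2)nc2cnc(N3CCN(C)CC3)cn12` has not yet been measured. It differs from compound 2 in one place: 4-bromo-2-methylphenyl in place of 4-chloro-2-fluorophenyl on a nitrogen on an aromatic ring. No step between measured compounds is shown for this assay; the shown data give no guide to how large a change of this kind turns out. Compound 3 is therefore expected to stay close to compound 2, with a step that need not go beyond the usual scatter in either direction. The expected step is a 1.3-fold lower number from compound 2 to compound 3 (0.11 log units; within the scatter). Compound 3 is estimated to give 8000 nM in this assay, with a range from 2500 nM to 25000 nM.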

Compound 3, half-maximal inhibitory concentration: 10900 nM
Compound 3: the middle estimate sits 1.4-fold (0.13 log units) below what was measured, within the range that was stated.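

Among the compounds shown here, the step at this position can now be read in this assay: 4-bromo-2-methylphenyl in place of 4-chloro-2-fluorophenyl on the nitrogen gives a 1.0-fold higher number from compound 2 to compound 3 (0.02 log units; within the scatter), a result the earlier compounds could not provide. On this evidence, the read-out does not separate these two aryl groups, although the halogen differs and a methyl group replaces the fluorine. No measurement shown explains this outcome.

Steps involving compound 1 cannot be read, so the 4-iodophenyl group adds nothing to this comparison. On these data alone, it remains open whether any group at this position would move the read-out beyond the scatter, for example a phenyl ring carrying an amine or a carboxylic acid.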